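Methylamino in place of 4-chlorophenyl on the shared core

The source may report more compounds than this note shows. Statements on the series, on what has been measured and on what is new or still open speak of the compounds shown alone.

In a functional assay on the whole organism for inhibition, with Rattus norvegicus as the target, with a stated time of 3.5 h, at a dose of 100 mg/kg by the oral route (on this read-out higher numbers stand for more inhibition at the one dose given (going by the name of the read-out) and lower numbers for less inhibition), compound 1 `Cc1nnc(-c2nsc3ccccc23)o1` gives 21% and compound 2 `Clc1ccc(-c2nnc(-c3nsc4ccccc34)o2)cc1` gives 24%. Compound 2 holds the highest of the two numbers shown, yet the step of a number 3 percentage points higher from compound 1 to compound 2 (within the scatter) lies within the scatter, so the two values are not separated. Compound 3 `CNc1nnc(-c2nsc3ccccc23)o1` differs from compound 2 by methylamino in place of 4-chlorophenyl on an aromatic carbon. Going by the values given here, no measured step brings a methylamino group onto this carbon; the only step that alters this position stays within the scatter, so no change beyond the scatter is expected. Compound 3 is therefore estimated at 22%, with a range of 5% to 40%. The expected step is a number 2 percentage points lower from compound 2 to compound 3 (within the scatter).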

Compound 3, a percentage reported as inhibition, in the whole organism at one dose (the size of the read-out at that dose, not a potency): 10%
Compound 3: the middle estimate sits 12 percentage points above what was measured; the measured number falls inside the stated range.
By their numbers in this assay, from the lowest: compound 3; then compounds 1 and 2 (each within the scatter of the next).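

This aromatic carbon is not indifferent in this assay: methylamino in place of 4-chlorophenyl gives a number 14 percentage points lower from compound 2 to compound 3 (beyond the scatter), and methylamino in place of methyl gives a number 11 percentage points lower from compound 1 to compound 3 (beyond the scatter), whereas the exchange of methyl for 4-chlorophenyl stayed within the scatter. Both steps are modest, and of the three groups compared at this place, only methylamino carries a hydrogen-bond donor. Nothing measured here accounts for the lower number.

Open, going by these compounds, is whether the lower number goes with the amine nitrogen or with its hydrogen. A dimethylamino or a methoxy group on this carbon would bear on that.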